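The compounds below may be only part of what the source reports. "The series", "measured", "known", "first", "only" and "open" are said of these compounds alone.

Working notes on the series, read in a functional assay on KB cells (Homo sapiens) for inhibition, read by sulforhodamine B assay; on this read-out lower numbers stand for stronger inhibition of growth and higher numbers for weaker inhibition of growth. Compound 1 (`c1ccc(-c2ccc(-c3ccc(-c4nc5ccccc5[nH]4)cc3)cc2)cc1`) gives 39700 nM and compound 3 (`FC(F)(F)Oc1ccc(-c2ccc(-c3ccc(-c4nc5ccccc5[nH]4)cc3)cc2)cc1`) gives 39100 nM, so these two sit together at the high end of the three numbers. Compound 2 (`Cc1ccc2[nH]c(-c3ccc(-c4ccc(-c5ccc(N(C)C)cc5)cc4)cc3)nc2c1`) gives 6240 nM, lower than compound 3 by more than the scatter.

The next change leads to compound 4 (`CN(C)c1ccc(-c2ccc(-c3ccc(-c4nc5ccccc5[nH]4)cc3)cc2)cc1`): dimethylamino in place of trifluoromethoxy on an aromatic carbon, para to a large group (dimethylamino in place of trifluoromethoxy on an aromatic carbon).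

Within the data shown here, one measured step bears on this directly: trifluoromethoxy in place of hydrogen gave a 1.0-fold lower number from compound 1 to compound 3 (0.01 log units; within the scatter), so those two substituents are not told apart here. Among the measured compounds shown here, no matched step covers dimethylamino. The closest evidence is compound 2 at 6240 nM, which carries dimethylamino but also a methyl on the shared core that compound 4 lacks. What that methyl contributes has not been measured, so the evidence is indirect and the range must stay wide. A lower number is expected, beyond the scatter, though perhaps not reaching the value of compound 2. The expected size is a 4.3-fold lower number from compound 3 to compound 4 (0.64 log units; beyond the scatter). For compound 4 the estimate is 9000 nM, with an expected range from 3000 nM to 25000 nM.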

Compound 4, concentration for 50% growth inhibition: 39300 nM
Compound 4: the middle estimate sits 4.4-fold (0.64 log units) below what was measured, and the stated range ends below it.
By their numbers in this assay, from the lowest: compound 2; then compounds 3, 4 and 1 (each within the scatter of the next).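

In this assay, dimethylamino on this aromatic carbon, para to a large group, is not told apart from trifluoromethoxy (a 1.0-fold higher number from compound 3 to compound 4 (0.00 log units; within the scatter)) or from hydrogen (a 1.0-fold lower number from compound 1 to compound 4 (0.00 log units; within the scatter)), so all three substituents now sit at one level on the shared core. Among these compounds, the single difference that separates compound 4 from the lower number of compound 2 is the methyl on the core: hydrogen in place of methyl gives a step beyond the scatter (a 6.3-fold higher number from compound 2 to compound 4 (0.80 log units; beyond the scatter)), which shows that dimethylamino alone does not bring the number of compound 2. No measurement at hand gives a reason for either result.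

On these data alone, it remains open whether the methyl on the core would lower the number with hydrogen or trifluoromethoxy at this position, or only together with dimethylamino. Also open, as far as these compounds go, are the effects of an ethyl group or a chlorine atom in place of that methyl, and of a carboxylic acid or a primary amine on the aromatic carbon para to a large group.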